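The compounds below may be only part of what the source reports. "The series", "measured", "known", "first", "only" and "open" are said of these compounds alone.

Compound 1 `CN(C)CCNc1nc(-c2ccc(NC(=O)Nc3ccc(Cl)cc3Cl)cc2)nc2ccsc12` and compound 2 `Cc1ccc(NC(=O)Nc2ccc(-c3nc(NCCN(C)C)c4sccc4n3)cc2)cc1` share one core and differ in the aryl group on the urea. In a functional assay on MKN-45 cells (Homo sapiens) for cytotoxicity, read by MTT assay, with a stated time of 72 h (a lower number here means a stronger inhibitor, a higher number a weaker inhibitor), compound 1 gives 2360 nM, and compound 2 gives 2380 nM. The change between them, (4-methylphenyl in place of 2,4-dichlorophenyl on an amide-type nitrogen), made the step of a 1.0-fold higher number from compound 1 to compound 2 (0.00 log units; within the scatter), so the two numbers cannot be told apart here.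

Compound 3 `CCN(CC)CCCNc1nc(-c2ccc(NC(=O)Nc3ccc(Cl)cc3Cl)cc2)nc2c(Cl)c(Cl)sc12` carries a different core; the difference between the two cores is not broken down here. In this assay compound 3 gives 5720 nM, the highest of the three numbers, with the nearest of the others, compound 2, a clear distance away. Compound 4 `CCN(CC)CCCNc1nc(-c2ccc(NC(=O)Nc3ccc(C)cc3)cc2)nc2c(Cl)c(Cl)sc12` is related to compound 3 by the same change, (4-methylphenyl in place of 2,4-dichlorophenyl on an amide-type nitrogen), that links compound 1 to compound 2, at the same place on an amide-type nitrogen.

Since the earlier step of a 1.0-fold higher number from compound 1 to compound 2 (0.00 log units; within the scatter) left the number essentially unchanged, compound 4 is expected to show a step of about a 1.0-fold lower number from compound 3 to compound 4 (0.02 log units; within the scatter) from compound 3, resting on that single precedent. Compound 4 is therefore estimated at 5500 nM in this assay, with a range from 2400 nM to 12500 nM.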

Compound 4, half-maximal inhibitory concentration: 3320 nM
Compound 4: the middle estimate sits 1.7-fold (0.22 log units) above what was measured, within the range that was stated.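

In this assay, placing 4-methylphenyl where 2,4-dichlorophenyl stood on the amide-type nitrogen gives a 1.7-fold lower number from compound 3 to compound 4 (0.24 log units; within the scatter), a step that lies within the scatter and so cannot be told from no change. Set beside the earlier step, it shows that the change behaved alike on both cores, with nothing to separate the two results: the same change on two cores in this assay, a 1.0-fold higher number (0.00 log units; within the scatter) from compound 1 to compound 2 and a 1.7-fold lower number (0.24 log units; within the scatter) from compound 3 to compound 4, 1.7-fold (0.24 log units) apart, within the scatter of two such steps. This shows only that, for these two pairs, the aryl exchange can be carried from one core to the other without a readable difference; it does not show that the same would hold on any further core, or that the aryl group on the urea never matters in this series.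

The compounds shown leave open how other aryl groups on the same nitrogen, such as unsubstituted phenyl, 4-methoxyphenyl or 4-trifluoromethylphenyl, would read. They also leave open whether the exchange would behave the same way with a morpholine or a pyrrolidine at the end of the amine chain.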